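This account rests on a few compounds, and the source may have more. Where it says the series, first, only, none or still open, it means among the compounds named here.

Of the compounds shown here, two share a core and have been measured in a functional assay on A549 cells (Homo sapiens) for cytotoxicity, read by MTT assay; a lower number here means a stronger inhibitor, a higher number a weaker inhibitor. Compound 1, `CCn1cc(-c2nc3ccc([N+](=O)[O-])cc3o2)c(=O)c2cc(F)c(N3CCNC(C)C3)c(F)c21`, gives 900 nM. Compound 2, `CCn1cc(C(=O)Nc2ccc(Cl)cn2)c(=O)c2cc(F)c(N3CCNC(C)C3)c(F)c21`, gives 3300 nM; of the two numbers, compound 2 has the higher one, and its gap to compound 1 lies beyond the scatter. Compound 3, `CCn1cc(C(=O)Nc2cc([N+](=O)[O-])ccc2F)c(=O)c2cc(F)c(N3CCNC(C)C3)c(F)c21`, carries 2-fluoro-5-nitrophenyl in place of 5-chloropyridin-2-yl on an amide-type nitrogen. For the measured compounds named here, no measured step matches this change, so the expectation for compound 3 in this assay is only loosely anchored, and the step from compound 2 is expected to be a 1.7-fold lower number from compound 2 to compound 3 (0.22 log units; within the scatter), a small lowering not clearly beyond the scatter. Compound 3 is estimated to give 2000 nM, within a range from 600 nM to 6500 nM.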

Compound 3, half-maximal inhibitory concentration: 1700 nM
Estimate against measurement, compound 3: 1.2-fold (0.07 log units) above, and the stated range covers the measured number.
By their numbers in this assay, from the lowest: compounds 1, 3 and 2 (each within the scatter of the next, the first and the last beyond it).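

On the amide-type nitrogen, 2-fluoro-5-nitrophenyl in place of 5-chloropyridin-2-yl gives a 1.9-fold lower number from compound 2 to compound 3 (0.29 log units; within the scatter) in this assay. This position therefore takes a carbon-only aromatic ring with more heavy atoms in place of a ring holding nitrogen, with no shift beyond the normal spread of repeat measurements. No measured property is available to explain this result.

On these data alone, the fluorine and the nitro group enter together, so what each does alone stays open. Also open, as far as these compounds go, is how a plain ethyl chain or a morpholine in place of the ring would read in this assay.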